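A few compounds are considered here, and "the series" means these few. Any claim that something is new, unique, unknown or untested is made for them only; others in the source may bear on it.

Measured so far:
- Compound 1, `Cc1c(OCCCCOc2ccccc2C(=O)O)ccc(C(=O)CC2CCCC2)c1O` — in an assay on HEK293 cells for positive allosteric modulation of metabotropic glutamate receptor 2 (Rattus norvegicus), read by thallium flux, with a stated time of 2.5 min (a higher number here means a larger maximal response, a lower number a smaller maximal response), compound 1 gives 98.8%
- Compound 2, `Cc1c(OCCCCOc2cccc(C(=O)O)c2)ccc(C(=O)CC(C)C)c1O` — in this assay compound 2 gives 84.5%

Among the two numbers, compound 2 stands lowest, and the nearest number, that of compound 1, lies higher by a gap that is beyond the usual scatter of this kind of measurement. Among the compounds with values here, compound 1 and compound 2 differ in more than one place, so their gap is not tied to a single change and no step between them is reported here.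

The next compound, compound 3, `Cc1c(OCCCCOc2ccccc2C(=O)O)ccc(C(=O)CC(C)C)c1O`, is built from compound 2 by one change:

2-carboxyphenyl in place of 3-carboxyphenyl on an oxygen on a saturated carbon

Compound 3 thus carries the same carboxyphenyl arrangement as compound 1 on the chain oxygen, while keeping the rest of compound 2 unchanged. Because compound 1 gives 98.8% in this assay with that arrangement, a rise is expected for compound 3, though of a size that may or may not clear the scatter, since the two measured compounds differ elsewhere as well. The expected step of a number 7.5 percentage points higher from compound 2 to compound 3 (within the scatter) is therefore upward and moderate. For compound 3 the estimate in this assay is 92%, expected to fall between 80% and 104%.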

Compound 3, largest response reached (reported as percent of maximum), in percent of the reference or control that the assay uses: 92.4%
For compound 3 the middle estimate is 0.4 percentage points below the measured one, and the stated range covers the measured number.
By their numbers in this assay, from the lowest: compounds 2, 3 and 1 (each within the scatter of the next, the first and the last beyond it).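

In this assay, 2-carboxyphenyl in place of 3-carboxyphenyl on the oxygen of the saturated chain gives a number 7.9 percentage points higher from compound 2 to compound 3 (within the scatter), so this exchange of two groups with the same atoms, joined differently, is not resolved from the scatter at this place. Compound 3 also links the series at a second place, where isopropyl in place of cyclopentyl on the saturated chain carbon bound to a carbonyl carbon gives a number 6.4 percentage points lower from compound 1 to compound 3 (within the scatter), so neither single change, read on its own, lies beyond the scatter. Nothing available here accounts for the size of either step.

The compounds shown leave open how 4-carboxyphenyl on the same oxygen, or a phenyl ring carrying a tetrazole instead of the carboxylic acid, would read in this assay. They also leave open whether cyclohexyl or a straight butyl chain on the saturated chain carbon bound to a carbonyl carbon would stay within the scatter of compound 3 92.4%.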